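Replacing the bromo of compound 2 with hydrogen

This account rests on a few compounds, and the source may have more. Where it says the series, first, only, none or still open, it means among the compounds named here.

Among the compounds with values here, in a functional assay on KG-1 cells (Homo sapiens) for cytotoxicity, read by luminescence and CellTiter-Glo, with a stated time of 3 days (a lower number here means a stronger inhibitor, a higher number a weaker inhibitor), three compounds have numbers so far. Compound 1 (`N#Cc1ccc(NC(=O)c2ccc(Br)cc2O)c(Cl)c1`) gives 790 nM and compound 3 (`N#Cc1ccc(NC(=O)c2cc(F)ccc2O)cc1`) gives 2670 nM in that measurement. Compound 2 (`O=C(Nc1cc(C(F)(F)F)cc(C(F)(F)F)c1)c1cc(Br)c(-c2ccccc2)cc1O`) gives 300 nM and stands lowest of the three, with its gaps to both others beyond the scatter.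

Compound 4 (`O=C(Nc1cc(C(F)(F)F)cc(C(F)(F)F)c1)c1ccc(-c2ccccc2)cc1O`) is compound 2 with hydrogen in place of bromo on an aromatic carbon. That carbon is ortho to a phenyl group and para to a hydroxy group. Within the data shown here, no measured pair isolates this change, so the expectation rests on indirect evidence only. Compound 3, which has no bromo, gives 2670 nM, and both measured compounds with a bromo read lower than it, but compound 3 also differs from them in other places, so this is a weak hint. A modest move toward a weaker number seems more likely than no change. The expected step in this assay is a 2.2-fold higher number from compound 2 to compound 4 (0.34 log units; beyond the scatter) and would lie close to the edge of the scatter. For compound 4 the estimated value is 650 nM with an expected range from 200 nM to 2000 nM in this measurement.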

Compound 4, half-maximal inhibitory concentration: 860 nM
For compound 4 the middle estimate is 1.3-fold (0.12 log units) below the measured one; the range from low to high includes it.
By their numbers in this assay, from the lowest: compound 2; then compounds 1 and 4 (each within the scatter of the next); then compound 3.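

In this assay, within the data shown here, this is the first pair that isolates the bromo: hydrogen in its place on the aromatic carbon gives a 2.9-fold higher number from compound 2 to compound 4 (0.46 log units; beyond the scatter), a modest step but one that lies beyond the scatter. The bromo on this carbon, ortho to a phenyl group and para to a hydroxy group, therefore contributes to the lower number of compound 2, but it is not needed for a measurable cytotoxic read-out, as compound 4 still gives 860 nM. Nothing measured on these compounds bears on what lies behind this step.

The compounds shown leave open whether a chloro, a methyl or a methoxy group on this carbon would read closer to compound 2 or to compound 4. As far as these compounds go, it is also open whether a step of this size would carry over to a different background, such as one where the phenyl group bears an amine or a carboxylic acid, since a single pair defines the effect so far.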